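A Carbamoyl Replaces a Benzyl on the Ring Nitrogen

The source may hold more compounds than are shown below. What is called first, only, known or untested is meant among the compounds shown, and "the series" means these compounds.

Measured so far in a functional assay on cells (T-cell, Homo sapiens) for inhibition; a higher number here means a weaker inhibitor, a lower number a stronger inhibitor:
compound 1, `COc1ccc(-c2cnc3nc(N)nc(NC(C)C)c3n2)cc1OC`, gives 600 nM
compound 2, `COc1ccc(-c2cnc3nc(N)nc(NCc4ccccc4)c3n2)cc1OC`, gives 13000 nM
compound 3, `COc1ccc(-c2cnc3nc(N)nc(N4CCN(Cc5ccccc5F)CC4)c3n2)cc1OC`, gives 700 nM

Compound 3 sits close to compound 1, the two numbers lying within the usual scatter of each other, while compound 2 returns a far higher number than either. Only one single-point step is available among these three: a 22-fold higher number from compound 1 to compound 2 (1.34 log units; beyond the scatter), a large step brought about by benzyl in place of isopropyl on a nitrogen on an aromatic ring.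

Compound 4, `COc1ccc(-c2cnc3nc(N)nc(N4CCN(C(=O)NCc5ccc(F)cc5)CC4)c3n2)cc1OC`, has not yet been measured. It differs from compound 3 as follows: (4-fluorobenzyl)carbamoyl in place of 2-fluorobenzyl on an amine nitrogen in a ring. Going by the values given here, this change sits on an amine nitrogen in a ring, not on the aromatic ring where the one measured step took place, and it exchanges one fluorobenzyl-bearing group for another rather than an alkyl for a benzyl. The step from compound 1 to compound 2 therefore gives only loose guidance here. A modest weakening is expected, with the direction uncertain, as a 2.1-fold higher number from compound 3 to compound 4 (0.33 log units; beyond the scatter). For compound 4 the estimate in this assay is 1500 nM, within a range from 400 nM to 6000 nM.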

Compound 4, half-maximal inhibitory concentration: 37 nM
Compound 4: the middle estimate sits 41-fold (1.61 log units) above what was measured, and the stated range ends above it.
By their numbers in this assay, from the lowest: compound 4; then compounds 1 and 3 (each within the scatter of the next); then compound 2.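

In this assay, replacing 2-fluorobenzyl with (4-fluorobenzyl)carbamoyl on the amine nitrogen in the six-membered ring gives a 19-fold lower number from compound 3 to compound 4 (1.28 log units; beyond the scatter), which shows that the group on this nitrogen can strongly change the number and that a carbamoyl is tolerated here. The only earlier step, on the nitrogen on an aromatic ring, went towards a higher number, so this is the first step shown that goes towards a stronger inhibitor. The change is a combined one, adding a carbonyl and a nitrogen with its hydrogen while also moving the fluorine from the 2 to the 4 position of the benzyl group, and no measurement given here accounts for the gain.

The compounds shown leave open whether the carbamoyl or the place of the fluorine carries the step, a question that 4-fluorobenzyl directly on the ring nitrogen or a (2-fluorobenzyl)carbamoyl would separate. They also leave open whether the carbamoyl nitrogen with its hydrogen matters, as a plain 4-fluorophenylacetyl group in the same place would show, and whether the fluorine is needed at all, as an unsubstituted benzylcarbamoyl would show.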